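The source may hold more compounds than are shown below. What is called first, only, known or untested is meant among the compounds shown, and "the series" means these compounds.

Working notes on the halogen series. In an ADME assay on HeLa cells (Homo sapiens) for cytotoxicity, read by resazurin assay, with a stated time of 2 days (on this read-out lower numbers stand for stronger inhibition and higher numbers for weaker inhibition), compound 1 (`Cn1c([N+](=O)[O-])cnc1/C=C/c1cccc(Br)c1`) gives 87100 nM and compound 2 (`Cn1c([N+](=O)[O-])cnc1/C=C/c1cccc(Cl)c1`) gives 30200 nM as the lower of the two numbers. Compound 2 is therefore the reference point for the next comparison. Compound 3 (`Cn1c([N+](=O)[O-])cnc1/C=C/c1cccc(F)c1`) has not yet been measured. Its change from compound 2 is fluoro in place of chloro on an aromatic carbon, meta to a large group (fluoro in place of chloro on an aromatic carbon). Among the compounds with values here, only one measured step bears on this change, namely chloro in place of bromo on an aromatic carbon (a 2.9-fold lower number from compound 1 to compound 2 (0.46 log units; beyond the scatter)). That step was modest and beyond the scatter. A single step between two compounds sets no trend, so the direction remains uncertain. A further modest move toward a lower number in this assay is the working expectation, although a result within the scatter of compound 2 would fit the data equally well. The estimated step is modest (a 1.5-fold lower number from compound 2 to compound 3 (0.18 log units; within the scatter)) and points the same way. Compound 3 is expected at 20000 nM with an estimated range from 7000 nM to 60000 nM when measured.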

Compound 3, half-maximal inhibitory concentration: > 100000 nM
Compound 3 ended at the assay's limit (the forecaster's own chance of this, stated with the estimate: 5%); at least 5.0-fold (0.69 log units) between middle value and limit.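

On this position, meta to a large group, halogen exchange does not run in one direction in this assay: a 2.9-fold lower number from compound 1 to compound 2 (0.46 log units; beyond the scatter) is followed by an at least 3.3-fold higher number from compound 2 to compound 3 (0.51 log units; beyond the scatter), so the fluoro member reverses the direction set by the earlier pair. Compound 2, the chloro member, therefore holds the lowest number of the three, with its steps to both other compounds printed as beyond the scatter, and the earlier single step gave no guide to what the fluoro member would do. Against the bromo member there is an at least 1.1-fold higher number from compound 1 to compound 3 (0.05 log units; that floor lies within the scatter), so no order can be stated between those two compounds, and the reading of compound 3 is a limit of the assay and not a number: the limit of > 100000 nM in this assay, at which 1 of the 3 values shown sits.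

From the compounds shown here alone, the true size of the gap between the chloro and fluoro members stays open while compound 3 rests at that limit. Also open, going by these compounds, is whether a group other than a halogen at this position, such as a methoxy group, a nitrile or an amine, would give a number lower than that of compound 2.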